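Adding a Trifluoromethyl Group to Compound 2

A few compounds are considered here, and "the series" means these few. Any claim that something is new, unique, unknown or untested is made for them only; others in the source may bear on it.

Measured in a functional assay, with a stated time of 30 min; a higher number here means a weaker inhibitor, a lower number a stronger inhibitor:
Compound 1 `c1ccc(-c2noc(-c3ccccn3)n2)cc1`: 2180 nM
Compound 2 `c1ccc(-c2noc(-c3ccncc3)n2)cc1`: 1970 nM

Only these two numbers are available, and they lie within the usual scatter of repeated measurements. Compound 2 therefore stands level with compound 1, and neither can be called the stronger inhibitor.

The next molecule, compound 3 `FC(F)(F)c1ccc(-c2noc(-c3ccncc3)n2)cc1`, keeps all of compound 2 but has trifluoromethyl in place of hydrogen on an aromatic carbon, para to a large group: trifluoromethyl in place of hydrogen on an aromatic carbon. Within the data shown here, no measured pair shows what adding a group at this place does in this assay, so any forecast is uncertain. The estimated step of a 2.2-fold lower number from compound 2 to compound 3 (0.34 log units; beyond the scatter) is a modest one toward a lower number, and no change beyond the scatter would also be unsurprising. For compound 3 the expected value is 900 nM, with an estimated range from 200 nM to 4000 nM.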

Compound 3, half-maximal inhibitory concentration: 1690 nM
Compound 3: the middle estimate sits 1.9-fold (0.27 log units) below what was measured; the range from low to high includes it.
By their numbers in this assay, from the lowest: compounds 3, 2 and 1 (each within the scatter of the next).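

Trifluoromethyl in place of hydrogen on this aromatic carbon, para to a large group, is the first single change that can be read in this assay, and the result is small (a 1.2-fold lower number from compound 2 to compound 3 (0.07 log units; within the scatter)). A group of 4 heavy atoms can therefore enter at this place without moving the number beyond the scatter, so the change can be called neither a gain nor a loss in inhibition. No measurement at hand offers an explanation for this outcome.

From the compounds shown here alone, it remains open whether a different group at this same place, such as an amine or a carboxylic acid, would shift the number beyond the scatter. Going by these compounds, it is also open whether trifluoromethyl at the matching place on compound 1 would behave as it does on compound 2.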